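Alkyne hydroxyurea series: the stereodefined methyl analogue

The source may hold more compounds than are shown below. What is called first, only, known or untested is meant among the compounds shown, and "the series" means these compounds.

Measured so far in an assay for inhibition of Polyunsaturated fatty acid 5-lipoxygenase (Homo sapiens), read by HPLC, with stated times of 15 min and 10 min; on this read-out higher numbers stand for weaker inhibition and lower numbers for stronger inhibition:
compound 1 `CC(C#Cc1cccc(C(=O)NCc2ccccc2C(F)(F)F)c1)N(O)C(N)=O` gives 700 nM
compound 2 `CCCC(C#Cc1cccc(C(=O)NCc2ccccc2C(F)(F)F)c1)N(O)C(N)=O` gives 300 nM
compound 3 `CC(C)C(C#Cc1cccc(C(=O)NCc2ccccc2C(F)(F)F)c1)N(O)C(N)=O` gives 500 nM

Compound 3 stands second highest of the three numbers; its nearest neighbour is compound 1, a step within the scatter, and compound 2 lies furthest, also within the scatter. Compound 4 `C[C@@H](C#Cc1cccc(C(=O)NCc2ccccc2C(F)(F)F)c1)N(O)C(N)=O` differs from compound 3 by 1-(carbamoyl(hydroxy)amino)ethyl in place of 1-(carbamoyl(hydroxy)amino)-2-methylpropyl on a triple-bonded carbon. Compound 4 carries the same chain as compound 1, now with a defined stereocentre. The bearing steps are a 1.4-fold lower number from compound 1 to compound 3 (0.15 log units; within the scatter) and a 1.7-fold higher number from compound 2 to compound 3 (0.22 log units; within the scatter), both small, and a 2.3-fold lower number from compound 1 to compound 2 (0.37 log units; beyond the scatter), modest. The number for compound 1 is the direct anchor; a single stereoisomer may sit on either side of it. Compound 4 is therefore expected at 600 nM (range 250 nM to 1500 nM), a step of a 1.2-fold higher number from compound 3 to compound 4 (0.08 log units; within the scatter), not beyond the scatter.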

Compound 4, half-maximal inhibitory concentration: 700 nM
Beside the measured number, compound 4's estimate is 1.2-fold (0.07 log units) below it; the measured number falls inside the stated range.
By their numbers in this assay, from the lowest: compounds 2, 3, 1 and 4 (each within the scatter of the next, the first and the last beyond it).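

The step to the defined S configuration reads as no change at the digits printed from compound 1 to compound 4 (within the scatter) in this assay, so at this saturated chain carbon the drawn S form shows no separation from the form without a drawn configuration. The stereodefined compound also gives firmer footing to the chain comparisons: a 1.4-fold higher number from compound 3 to compound 4 (0.15 log units; within the scatter), and a 2.3-fold higher number from compound 2 to compound 4 (0.37 log units; beyond the scatter). The pair with no change differs in a single respect: the fact that one of compounds 1 and 4 is drawn with a defined configuration and the other without, at the place where they differ

As far as these compounds go, the number for the R form remains open. So does whether a longer chain such as pentyl, or a cyclopropyl group, at this carbon would go beyond compound 2.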